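Swapping trifluoromethyl for methoxy on an aromatic carbon

The source may report more compounds than this note shows. Statements on the series, on what has been measured and on what is new or still open speak of the compounds shown alone.

Among the measured compounds shown here, in an ADME assay on a cell-free system (serum, Homo sapiens) for protein binding (on this read-out lower numbers stand for a smaller free fraction and higher numbers for a larger free fraction), compound 1 `CC(=O)N1CCN(c2cccc(-c3cc(C#N)c4c(N)ncnn34)c2)C(=O)C1(C)C` gives 0.3 and holds the only number so far. For compound 2 `CC(=O)N1CCN(c2cc(-c3cc(Cl)c4c(N)ncnn34)ccc2C(F)(F)F)C(=O)C1(C)C` the entry reads "not determined" (no result reported) so it has no place on this scale. Compound 3 `COc1ccc(-c2cc(Cl)c3c(N)ncnn23)cc1N1CCN(C(C)=O)C(C)(C)C1=O` differs from compound 2 methoxy in place of trifluoromethyl on an aromatic carbon with methoxy in place of trifluoromethyl on an aromatic carbon, ortho to a large group and para to a large group. For the measured compounds named here, no measured step guides this change, so compound 1 at 0.3 is the sole anchor for the expectation. Compound 3 is expected at about 0.25 with an estimated range from 0.12 to 0.45 in this assay once measured.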

Compound 3, unbound fraction: 0.17
Compound 3: the middle estimate sits 1.5-fold (0.17 log units) above what was measured; measured number inside the range.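

Among the compounds shown here, compound 2 offers no number in this assay, so no step from it to compound 3 can be read. Going by these compounds, what swapping trifluoromethyl for methoxy does to the unbound fraction stays open, and no evidence at hand bears on this.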